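Swapping methoxy for chloro on a weak cytotoxic series

This account rests on a few compounds, and the source may have more. Where it says the series, first, only, none or still open, it means among the compounds named here.

Measured compounds:
- compound 1, `C/C(=N\NC(=O)CC#N)c1ccc(S(=O)(=O)N2CCCCC2)cc1`: 44200 nM
- compound 2, `CCOC(=O)c1c(-c2ccc(OC)cc2)c(C#N)c(=O)n(/N=C(\C)c2ccc(S(=O)(=O)N3CCCCC3)cc2)c1N`: 51200 nM

Both numbers come from a functional assay on MCF7 cells (Homo sapiens) for cytotoxicity, read by sulforhodamine B assay, with a stated time of 48 h; on this read-out lower numbers stand for stronger inhibition and higher numbers for weaker inhibition. Compound 1 gives 44200 nM and compound 2 gives 51200 nM; both sit far up the concentration scale, meaning only weak cytotoxicity. Compound 2 has the highest of the two numbers, but the nearest number, that of compound 1, lies within the usual scatter of such measurements, so the two cannot be told apart.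

Compound 3, `CCOC(=O)c1c(-c2ccc(Cl)cc2)c(C#N)c(=O)n(/N=C(\C)c2ccc(S(=O)(=O)N3CCCCC3)cc2)c1N`, keeps the whole framework of compound 2 and changes one substituent: chloro in place of methoxy on an aromatic carbon. Among the compounds with values here, no measured pair in this set shows what such a swap does here, so nothing beyond the structural change itself can guide the expectation. With both measured compounds already weak and close together, the expected step in this assay from compound 2 to compound 3 is small, in no particular direction, and most likely not beyond the scatter; the estimate means a 1.1-fold lower number from compound 2 to compound 3 (0.06 log units; within the scatter). Compound 3 is therefore expected to give about 45000 nM, with a plausible range from 18000 nM to 110000 nM.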

Compound 3, half-maximal inhibitory concentration: 20600 nM
The estimate for compound 3 lay 2.2-fold (0.34 log units) above the measured number; measured number inside the range.
By their numbers in this assay, from the lowest: compound 3; then compounds 1 and 2 (each within the scatter of the next).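

Within the data shown here, replacing methoxy with chloro on the aromatic ring gives a 2.5-fold lower number from compound 2 to compound 3 (0.40 log units; beyond the scatter) in this assay, the first comparison in this set where only one group changes. The rest of the framework stays the same, so this position, para to a large group, is not indifferent: a single substituent there can shift the number by more than ordinary repeat measurements would. Even so, compound 3 at 20600 nM remains far up the concentration scale, and nothing measured here offers a reason for the step, so it stands only as an observation.

A single swap gives only two points at this position, so it cannot show whether the lower number belongs to chloro specifically or whether other groups placed there, such as fluoro, methyl, an amine or a carboxylic acid, would move it further or reverse it. The compounds shown also leave open whether the same swap would have a similar effect on another framework, and whether changes elsewhere, such as an amide in place of the ethyl ester, would matter more than this one.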